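Working notes: from compound 2 to compound 3

A few compounds are considered here, and "the series" means these few. Any claim that something is new, unique, unknown or untested is made for them only; others in the source may bear on it.

Measured in an ADME assay on A549 cells (Homo sapiens) for cytotoxicity, read by resazurin assay, with a stated time of 48 h; on this read-out lower numbers stand for higher toxicity in this test and higher numbers for lower toxicity in this test:
- compound 1 `CC(C)Nc1ccc(NC(=O)c2cc(Cl)ccc2O)c(Cl)c1`: 11000 nM
- compound 2 `CCCCCCC(C)Nc1ccc(NC(=O)c2cc(Cl)ccc2O)c(Cl)c1`: 23500 nM

Compound 2 holds the higher of the two numbers in this assay, and its gap to compound 1 lies beyond the usual scatter. The next compound to be tested, compound 3 `O=C(Nc1ccc(NCC2CC2)cc1Cl)c1cc(Cl)ccc1O`, carries cyclopropylmethyl in place of 1-methylheptyl on a nitrogen on an aromatic ring.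

Among the compounds with values here, only one measured step bears on this change: a 2.1-fold higher number from compound 1 to compound 2 (0.33 log units; beyond the scatter), modest in size, with pentyl in place of hydrogen on a saturated chain carbon. Within the data shown here, a single step shows no pattern, and no measured compound carries a three-membered ring, so the reading is tentative. The group entering compound 3 is smaller than 1-methylheptyl, so that step is expected to run in reverse at a similar size, towards the number of compound 1 at 11000 nM. The expected change is a 1.9-fold lower number from compound 2 to compound 3 (0.27 log units; within the scatter), a lower number in this assay. For compound 3 the estimate is 12500 nM, with an expected range of 5500 nM to 27000 nM.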

Compound 3, half-maximal cytotoxic concentration: 14400 nM
Estimate against measurement, compound 3: 1.2-fold (0.06 log units) below; the measured number falls inside the stated range.
By their numbers in this assay, from the lowest: compounds 1, 3 and 2 (each within the scatter of the next, the first and the last beyond it).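

In this assay, within the data shown here, the change puts a three-membered non-aromatic ring of carbon only on a nitrogen on an aromatic ring for the first time, and the read-out stays within the scatter of both open-chain comparators, with a 1.6-fold lower number from compound 2 to compound 3 (0.21 log units; within the scatter) and a 1.3-fold higher number from compound 1 to compound 3 (0.12 log units; within the scatter). This position therefore accepts cyclopropylmethyl without a separable change from either 1-methylheptyl or isopropyl, although compound 1 and compound 2 remain separated beyond the scatter, so compound 3 neither strengthens nor contradicts a link between group size and the read-out. No supporting evidence bears on why these three groups give these numbers.

On these data alone, whether a group carrying an amine or a carboxylic acid on this nitrogen, or a larger ring such as cyclohexyl, would move the number outside the span of these three compounds remains open. Also open, as far as these compounds go, is whether a longer chain would extend a 2.1-fold higher number from compound 1 to compound 2 (0.33 log units; beyond the scatter) or whether that step is specific to 1-methylheptyl.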